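From dimethylamino to 2-methoxyphenyl on the shared core

This account rests on a few compounds, and the source may have more. Where it says the series, first, only, none or still open, it means among the compounds named here.

Among the compounds with values here, in a physicochemical assay for lipophilicity, at pH 7.4 (a higher number here means a more lipophilic compound, a lower number a more polar compound), compound 1 (`Cc1n[nH]c(-c2ncc3c(N(C)C)ccnc3c2O)n1`) gives -0.6 and holds the lower of the two numbers available so far. Compound 2 (`Cc1n[nH]c(-c2ncc3c(NCc4ccc(Cl)cc4)ccnc3c2O)n1`) sits at 4.4 and so stands well beyond the scatter above it. Compound 3 (`COc1ccccc1-c1ccnc2c(O)c(-c3nc(C)n[nH]3)ncc12`) is still unmeasured and differs from compound 1 in one place (2-methoxyphenyl in place of dimethylamino on an aromatic carbon) with 2-methoxyphenyl in place of dimethylamino on an aromatic carbon, opposite the ring nitrogen. Within the data shown here, no measured pair shows this change, so the expectation rests only on the structural change and the two numbers. A rise beyond the scatter is expected, with a number 2.40 log units higher from compound 1 to compound 3 (beyond the scatter) as the estimated step, and the result should stay under the number for compound 2. Compound 3 is expected in this assay at 1.8 with 0.8 to 3 as its estimated range.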

Compound 3, distribution coefficient: 3.2
Beside the measured number, compound 3's estimate is 1.40 log units below it, and the stated range ends below it.
By their numbers in this assay, from the lowest: compound 1; then compound 3; then compound 2.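

In this assay, within the data shown here, the change to 2-methoxyphenyl in place of dimethylamino, on an aromatic carbon opposite the ring nitrogen, gives a number 3.80 log units higher from compound 1 to compound 3 (beyond the scatter) and is the first step measured at this position on the shared core. The two groups match in hydrogen-bond donors, hydrogen-bond acceptors and net charge, so this large step comes with no change in those counts, while the entering group brings a six-membered aromatic ring of carbon only. Compound 3 at 3.2 still stands under compound 2 at 4.4 in the printed values. Nothing available here accounts for the size of this step.

Going by these compounds, how much of the step belongs to the methoxy group and how much to the aromatic ring stays open. So does what an unsubstituted phenyl, a pyridine ring or a morpholine would give at this place.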